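Series notes: compound 4, methoxy in place of chloro

The compounds below may be only part of what the source reports. "The series", "measured", "known", "first", "only" and "open" are said of these compounds alone.

Measured compounds, antiproliferative read-out:
compound 1 `Cc1ccc(NCc2cn(-c3ccccc3)nc2-c2ccc(Cl)cc2)cc1` gives 3480 nM
compound 2 `Fc1ccc(NCc2cn(-c3ccccc3)nc2-c2ccc(Cl)cc2)cc1` gives 2120 nM
compound 3 `Cc1ccc(NCc2cn(-c3ccccc3)nc2-c2ccc(C)cc2)cc1` gives 7380 nM

All three values come from a functional assay on B16-F10 cells (Mus musculus) for antiproliferative activity, read by MTT assay, with a stated time of 48 h; on this read-out higher numbers stand for weaker inhibition and lower numbers for stronger inhibition. Compound 2 has the lowest number of the three, but its gap to compound 1 is within the scatter, a 1.6-fold lower number from compound 1 to compound 2 (0.22 log units; within the scatter), so no order between those two is claimed; only compound 3 stands clearly apart from it.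

Compound 4 `COc1ccc(-c2nn(-c3ccccc3)cc2CNc2ccc(F)cc2)cc1` is compound 2 with methoxy in place of chloro on an aromatic carbon. Within the data shown here, no measured pair carries this exact change. The nearest step is the one on the same aromatic carbon, a 2.1-fold higher number from compound 1 to compound 3 (0.33 log units; beyond the scatter), where the chloro is also replaced by a group of a different kind, and it moved the number up modestly. The chloro-to-methoxy exchange is taken to behave in the same direction, with similar size, since nothing in the data separates a methoxy from a methyl at this place.

Compound 4 is therefore expected to give a somewhat higher number than compound 2, a 1.8-fold higher number from compound 2 to compound 4 (0.26 log units; within the scatter), because of the step of a 2.1-fold higher number from compound 1 to compound 3 (0.33 log units; beyond the scatter) seen for the same position. The estimate for compound 4 is 3900 nM, with a range from 1800 nM to 8500 nM.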

Compound 4, half-maximal inhibitory concentration: 6580 nM
Beside the measured number, compound 4's estimate is 1.7-fold (0.23 log units) below it; the range from low to high includes it.
By their numbers in this assay, from the lowest: compounds 2, 1, 4 and 3 (each within the scatter of the next, the first and the last beyond it).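

In this assay, 4-chlorophenyl to 4-methoxyphenyl gives a 3.1-fold higher number from compound 2 to compound 4 (0.49 log units; beyond the scatter), so this exchange on an aromatic carbon, para to a large group, moves the number beyond the scatter, and it does so in a compound that carries fluoro where compound 1 carries methyl. The only earlier step at this place was a 2.1-fold higher number from compound 1 to compound 3 (0.33 log units; beyond the scatter), so two different replacements of chloro, in two different backgrounds, now both give a higher number, and no pair shown goes against this; the pattern rests on these two pairs alone. No measurement shown bears on the reason for this rise, and the data give only the direction and size of the two steps.

The compounds shown leave open whether any replacement of chloro at this place gives a lower number, for instance an amine, a nitrile or a trifluoromethyl group, or whether a longer chain in place of the methoxy raises the number further. They also leave open whether the methoxy step would keep its size with methyl in place of the fluoro, since that pair is not among the compounds shown here.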